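The source may report more compounds than this note shows. Statements on the series, on what has been measured and on what is new or still open speak of the compounds shown alone.

Compound 2, with the structure `Clc1ccc(N2CC[C@H]3CN[C@H]3C2)cn1`, is the focus of this account. In a functional assay on HEK293 cells for agonist activity at Neuronal acetylcholine receptor; alpha3/beta4 (Homo sapiens), read by FLIPR (on this read-out higher numbers stand for an effect only at larger amounts of compound and lower numbers for an effect already at smaller amounts), compound 2 gives 29 nM. Among the three numbers in hand, compound 2 stands second highest: compound 3, `Clc1ccc(N2CC[C@@H]3CN[C@@H]3C2)cn1`, the mirror image in which both stereocentres are inverted, gives 25 nM in this assay, and compound 1, `c1cncc(N2CC[C@H]3CN[C@H]3C2)c1`, which carries hydrogen in place of the chloro, gives 48 nM in this assay.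

Two measured steps surround compound 2. The exchange of hydrogen for chloro on the aromatic carbon runs a 1.7-fold lower number from compound 1 to compound 2 (0.22 log units; within the scatter), and the inversion of configuration runs a 1.2-fold lower number from compound 2 to compound 3 (0.06 log units; within the scatter), a change that rests only on (the fact that compounds 2 and 3 differ only in the configuration as drawn). Both steps lie within the scatter.

The new compound is compound 4, `COc1ccc(N2CC[C@H]3CN[C@H]3C2)cn1`. It differs from compound 2 by methoxy in place of chloro on an aromatic carbon. Among the measured compounds shown here, of the measured steps, only the one from compound 1 to compound 2 concerns the same aromatic carbon, and it shows that placing a small substituent there alters the number by no more than the scatter. Neither step speaks to the exchange of chloro for methoxy itself. Compound 4 is therefore expected to differ little from compound 2, with a step of a 1.4-fold higher number from compound 2 to compound 4 (0.14 log units; within the scatter) in this assay, in no particular direction beyond the scatter. For compound 4 the estimate in this assay is 40 nM, within a range from 14 nM to 115 nM.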

Compound 4, half-maximal effective concentration: 1100 nM
Estimate against measurement, compound 4: 28-fold (1.44 log units) below, and the stated range ends below it.
By their numbers in this assay, from the lowest: compounds 3, 2 and 1 (each within the scatter of the next); then compound 4.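

Among the compounds shown here, at this position, on an aromatic carbon next to the ring nitrogen, the earlier compounds showed only that hydrogen and chloro give numbers within the scatter of each other in this assay and so gave no sign that the place responds to what it carries. Methoxy changes that picture, with a 38-fold higher number from compound 2 to compound 4 (1.58 log units; beyond the scatter) and a 23-fold higher number from compound 1 to compound 4 (1.36 log units; beyond the scatter) as two large steps that point the same way, so the insensitivity seen between compound 1 and compound 2 does not extend to every small group at this carbon; methoxy, with 2 heavy atoms and 1 hydrogen-bond acceptor, stands apart here from chloro, with 1 heavy atom and no acceptor. Nothing in the information at hand accounts for the size of this step.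

On these data alone, whether a methyl, an amine or an ethoxy at this carbon would stay close to compound 1 and compound 2 or move with compound 4 remains open, and with it whether the oxygen or the added carbon goes with the higher number. Also open, as far as these compounds go, is whether the mirror image of compound 4 would stay as close to compound 4 as compound 3 does to compound 2.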